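Replacing a Benzothiazole Amine with a Methoxyphenyl Amine

The compounds below may be only part of what the source reports. "The series", "measured", "known", "first", "only" and "open" are said of these compounds alone.

Measured compounds:
Compound 1 `COc1ccc(-c2c(C)nc(NC(=O)NC3CCCCC3)c(C)c2C(OC(C)(C)C)C(=O)O)cc1`: 19000 nM
Compound 2 `Cc1ccc(-c2c(C)nc(Nc3nc4ccccc4s3)c(C)c2C(OC(C)(C)C)C(=O)O)cc1C`: 6600 nM
Compound 3 `Cc1nc(NC(=O)NC2CCCCC2)c(C)c(C(OC(C)(C)C)C(=O)O)c1-c1ccc2c(c1)CCCO2`: 17000 nM

In an ADME assay on MT4 cells (Homo sapiens) for cytotoxicity, read by MTT assay (on this read-out higher numbers stand for lower toxicity in this test and lower numbers for higher toxicity in this test), compound 2 gives 6600 nM, the lowest of the three numbers, and its distance to both compound 3 and compound 1 lies beyond the scatter, so compound 2 is the most cytotoxic of the three in this assay. Compound 4 `COc1ccc(Nc2nc(C)c(-c3ccc(C)c(C)c3)c(C(OC(C)(C)C)C(=O)O)c2C)cc1` differs from compound 2 in one place: 4-methoxyphenyl in place of 1,3-benzothiazol-2-yl on a nitrogen on an aromatic ring. Among the compounds with values here, the only measured step, a 1.1-fold lower number from compound 1 to compound 3 (0.05 log units; within the scatter), concerns a different position, the aromatic group on an aromatic carbon, and it stays within the scatter; it says nothing about the group on the nitrogen. Within the data shown here, compound 1 and compound 3 carry a different group on that nitrogen and both show higher numbers than compound 2, so a change there can matter, but no pair shows what this particular swap does. Compound 4 is therefore expected to give 10000 nM, between 3500 nM and 30000 nM, an uncertain step of a 1.5-fold higher number from compound 2 to compound 4 (0.18 log units; within the scatter).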

Compound 4, half-maximal cytotoxic concentration: 28000 nM
Beside the measured number, compound 4's estimate is 2.8-fold (0.45 log units) below it, and the stated range covers the measured number.
By their numbers in this assay, from the lowest: compound 2; then compounds 3, 1 and 4 (each within the scatter of the next).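

In this assay, replacing 1,3-benzothiazol-2-yl with 4-methoxyphenyl on the nitrogen gives a 4.2-fold higher number from compound 2 to compound 4 (0.63 log units; beyond the scatter), so the group on this nitrogen can shift the read-out, here towards lower toxicity in this test. Within the data shown here, the only earlier step, a 1.1-fold lower number from compound 1 to compound 3 (0.05 log units; within the scatter), concerned the aromatic group on an aromatic carbon, which leaves this as the first pair to show a change at the nitrogen, with the rest of the molecule held the same. No measurement shown gives a reason for this step.

Still open, on these data alone, is whether the step comes from losing the two-ring benzothiazole or from gaining the methoxy group, a question that a plain phenyl or a 4-hydroxyphenyl on the same nitrogen could help settle. As far as these compounds go, it is also open whether this swap would give a similar step with a different aromatic group on the aromatic carbon.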